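The source may report more compounds than this note shows. Statements on the series, on what has been measured and on what is new or still open speak of the compounds shown alone.

The measured compounds:
Compound 1, `O=S(=O)(c1ccc(O)nn1)c1ccccc1F`, in a functional assay on the whole organism for inhibition, with Rattus norvegicus as the target, at a dose of 20 mg/kg (a lower number here means a weaker effect, a higher number a stronger effect of the compound at the dose given), gives 91%.
Compound 2, `O=S(=O)(c1ccc(C(F)(F)F)cc1)c1ccc(O)nn1`, in this assay gives 67%.
Compound 3, `O=S(=O)(Cc1cccc(C(F)(F)F)c1)c1ccc(O)nn1`, in this assay gives 88%.

Compound 3 stands second highest of the three numbers. Its nearest neighbour is compound 1, whose number is higher by a margin within the usual scatter, so the two cannot be ranked against each other. Compound 2 is furthest, with a number lower by a margin beyond the scatter. Among the measured compounds shown here, none of the three measured compounds differ from one another in a single place, so no step between measured compounds can be drawn.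

Compound 4, `O=S(=O)(Cc1cccc(C(F)(F)F)c1F)c1ccc(O)nn1`, has not yet been measured. It differs from compound 3 in one place: fluoro in place of hydrogen on an aromatic carbon. The fluoro enters on an aromatic carbon, ortho to a trifluoromethyl group. Compound 1 also carries a fluoro on an aromatic ring and gives a number close to that of compound 3, but the two are not a single-place pair, so only their two values can be spoken of. With nothing in the data tying such a change to a shift, the step from compound 3 to compound 4 is expected to be small, none beyond the scatter: a number 3 percentage points lower from compound 3 to compound 4 (within the scatter) is the expected step. Compound 4 is expected to give 85% in this assay, with a range from 70% to 96%.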

Compound 4, a percentage reported as inhibition, in the whole organism at one dose (the size of the read-out at that dose, not a potency): 61%
Beside the measured number, compound 4's estimate is 24 percentage points above it; measured number outside the range, below it.
By their numbers in this assay, from the lowest: compounds 4 and 2 (each within the scatter of the next); then compounds 3 and 1 (each within the scatter of the next).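

In this assay the replacement of hydrogen by fluoro on an aromatic carbon, ortho to a trifluoromethyl group, gives a number 27 percentage points lower from compound 3 to compound 4 (beyond the scatter) and is the only single-place change that can be read among these compounds. It shows that this carbon of the ring in compound 3 does not tolerate every change without effect: one fluoro, with the rest of the structure unchanged, is enough to move the number beyond the scatter. Nothing shown here bears on why the number moves.

The compounds shown leave open whether a chlorine atom or a methyl group on the same aromatic carbon would move the number as fluoro does, and whether fluoro on another carbon of that ring would do so. They also leave open whether the step depends on the trifluoromethyl group.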